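The compounds below may be only part of what the source reports. "The series", "measured", "known", "first", "only" and "open" are said of these compounds alone.

Measured so far:
- compound 1, `Cc1cn(C2CCN(Cc3cccc(OC4CCCC4)c3)CC2)c(=O)[nH]c1=O`: 30300 nM
- compound 2, `Cc1cn(C2CCN(Cc3cncc(Oc4cccc(OC(F)(F)F)c4)c3)CC2)c(=O)[nH]c1=O`: > 64000 nM
- compound 3, `Cc1cn(C2CCN(Cc3cc(Oc4ccccc4)ccn3)CC2)c(=O)[nH]c1=O`: > 64000 nM

For the measured compounds named here, in an ADME assay on MRC5 cells (Homo sapiens) for cytotoxicity, read by fluorescence and resazurin assay, with a stated time of 3 days (on this read-out lower numbers stand for stronger inhibition and higher numbers for weaker inhibition), compound 1 gives 30300 nM, the only plain number in the set. Compound 2 reaches only a limit of the assay, > 64000 nM. Compound 3 likewise stops at a limit, > 64000 nM. Compound 1 therefore stands as the single point from which a step can be read; the other two values tell only that they sit at the limit of > 64000 nM in this assay, at which 2 of the 3 values shown sit.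

The step to compound 4, `COc1cccc(Oc2cccc(CN3CCC(n4cc(C)c(=O)[nH]c4=O)CC3)c2)c1`, is 3-methoxyphenyl in place of cyclopentyl on an oxygen on an aromatic ring. Going by the values given here, no step between measured compounds is available to calibrate this change, so the expectation rests on compound 1 alone and on the fact that the two other members sit at the limit. The step from compound 1 to compound 4 is expected to be a 1.7-fold higher number from compound 1 to compound 4 (0.22 log units; within the scatter), a shift toward weaker inhibition of modest size, with a fair chance that only a limit is returned. Compound 4 is thus estimated at 50000 nM, within 20000 nM to 120000 nM.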

Compound 4, half-maximal inhibitory concentration: 25300 nM
Compound 4: middle estimate off by 2.0-fold (0.30 log units), on the high side; the measured number falls inside the stated range.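

In this assay, the change from cyclopentyloxy to 3-methoxyphenoxy gives a 1.2-fold lower number from compound 1 to compound 4 (0.08 log units; within the scatter). On an oxygen on an aromatic ring, a six-membered aromatic ring with 8 heavy atoms and 1 hydrogen-bond acceptor therefore reads the same as a five-membered non-aromatic ring with 5 heavy atoms and none. The series now has a second plain number, while the remaining values stay at a limit: the limit of > 64000 nM in this assay, at which 2 of the 4 values shown sit.

The compounds shown leave open whether the methoxy group matters at all, as a plain phenyl on the same oxygen would show. They also leave open whether a longer chain ending in an amine or a carboxylic acid, in place of the 3-methoxyphenyl, would shift the number beyond the scatter.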